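Changing the aromatic group on a ring nitrogen

The source may hold more compounds than are shown below. What is called first, only, known or untested is meant among the compounds shown, and "the series" means these compounds.

Values in a functional assay on PANC-1 cells (Homo sapiens) for inhibition, read by MTT assay, with a stated time of 24 h; a lower number here means a stronger inhibitor, a higher number a weaker inhibitor:
- compound 1 `CC1(C)[C@H]2CC[C@]1(C)N(Cc1cn(-c3ccccc3C#N)nn1)C(=O)C2`: 240 nM
- compound 2 `Cc1ccc(-n2cc(CN3C(=O)C[C@@H]4CC[C@@]3(C)C4(C)C)nn2)cc1`: 270 nM

Among the compounds with values here, only two compounds have been measured so far, and they cannot be told apart on these numbers. Compound 2 stands level with the other measured compound, and the two share the same core. Compound 3 `COc1cccc(-n2cc(CN3C(=O)C[C@@H]4CC[C@@]3(C)C4(C)C)nn2)c1` keeps that core and carries 3-methoxyphenyl in place of 4-methylphenyl on an aromatic nitrogen.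

Within the data shown here, one measured step bears on this change, since it swaps the group on that same nitrogen: a 1.1-fold higher number from compound 1 to compound 2 (0.05 log units; within the scatter), with 4-methylphenyl in place of 2-cyanophenyl. From this single small step, no shift beyond the scatter is expected in this assay. Among the measured compounds shown here, one step is thin evidence, however, and no measured compound carries a 3-methoxyphenyl group, so the expected range stays wide. The expected change is a 1.0-fold lower number from compound 2 to compound 3 (0.02 log units; within the scatter). For compound 3 the estimated value is 260 nM, with an expected range of 110 nM to 600 nM.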

Compound 3, half-maximal inhibitory concentration: 860 nM
Compound 3: middle estimate off by 3.3-fold (0.52 log units), on the low side; the measured number lies above the stated range.
By their numbers in this assay, from the lowest: compounds 1 and 2 (each within the scatter of the next); then compound 3.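

The group on this nitrogen is not free to vary without consequence: in this assay, the 3-methoxyphenyl group gives a weaker inhibitor than the 4-methylphenyl group (a 3.2-fold higher number from compound 2 to compound 3 (0.50 log units; beyond the scatter)) and also than the 2-cyanophenyl group (a 3.6-fold higher number from compound 1 to compound 3 (0.55 log units; beyond the scatter)). Within the data shown here, the first pair of compounds stood level and gave no sign of this, so that pair's result does not hold for every substituted phenyl group at this position, although the loss seen here is only modest. Nothing available explains the rise in the number, so the result records an effect at this position without giving its cause.

The swap from compound 2 to compound 3 changes both the substituent and its numbered place on the phenyl ring, so these compounds cannot show which of the two matters. A 3-methylphenyl or 4-methoxyphenyl group on the same nitrogen would separate those two changes, while a phenyl ring carrying an amine or a carboxylic acid would test how far this position tolerates other kinds of group.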